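Naphthalen-1-yl for Phenyl: Expected Permeability of Compound 3

The source may report more compounds than this note shows. Statements on the series, on what has been measured and on what is new or still open speak of the compounds shown alone.

Going by the values given here, compound 2 `c1ccc(-c2ccc3c(NCCCNCc4ccco4)ccnc3c2)cc1` stands highest of the two numbers so far: in an ADME assay for permeability, using PAMPA, with a stated time of 30 min, at pH 7.4 (on this read-out higher numbers stand for higher permeability and lower numbers for lower permeability), compound 2 gives 237 10^-6 cm/s, while compound 1 `c1ccc(Cc2ccc3c(NCCCNCc4ccco4)ccnc3c2)cc1` gives 23 10^-6 cm/s, the step being a 10-fold higher number from compound 1 to compound 2 (1.01 log units; beyond the scatter). Compound 3 `c1coc(CNCCCNc2ccnc3cc(-c4cccc5ccccc45)ccc23)c1` differs from compound 2 by naphthalen-1-yl in place of phenyl on an aromatic carbon. No measured step covers this change; the one step shown concerns a different pair of groups, and it was large. Because compound 2 already gives 237 10^-6 cm/s, compound 3 is expected to show no step beyond the scatter, a 1.1-fold higher number from compound 2 to compound 3 (0.02 log units; within the scatter), with an estimate of 250 10^-6 cm/s in this assay and a range from 100 10^-6 cm/s to 550 10^-6 cm/s.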

Compound 3, apparent permeability: 237 10^-6 cm/s
The estimate for compound 3 lay 1.1-fold (0.02 log units) above the measured number, and the stated range covers the measured number.
By their numbers in this assay, from the lowest: compound 1; then compounds 2 and 3 (each within the scatter of the next).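

In this assay, the position takes naphthalen-1-yl in place of phenyl, adding a second six-membered aromatic ring of carbon only, with no change at the digits printed from compound 2 to compound 3 (within the scatter) at this aromatic carbon. The large step first seen with phenyl in place of benzyl also holds for the larger group, with a 10-fold higher number from compound 1 to compound 3 (1.01 log units; beyond the scatter) in place of benzyl. No measurement at hand bears on the reason for this result. Still open, from the compounds shown here alone, is whether naphthalen-2-yl would match naphthalen-1-yl here. An amine or a carboxylic acid at this position could give a quite different number.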